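Working notes on two measured amides and one untested

This account rests on a few compounds, and the source may have more. Where it says the series, first, only, none or still open, it means among the compounds named here.

Measured in an ADME assay on RAW264.7 cells (Mus musculus) for cytotoxicity, read by MTT assay, with a stated time of 72 h, tested at 100 uM; on this read-out lower numbers stand for a weaker effect and higher numbers for a stronger effect at the one concentration tested:
Compound 1 `O=C(Cn1c(=O)oc2cc([N+](=O)[O-])ccc21)Nc1ccccn1` gives 47.3%.
Compound 2 `O=C(Cn1c(=O)oc2cc([N+](=O)[O-])ccc21)Nc1ccccc1` gives 26.4%.

For the measured compounds named here, compound 1 stands highest of the two numbers; its nearest neighbour is compound 2, and the only measured step, a number 20.9 percentage points lower from compound 1 to compound 2 (beyond the scatter), is beyond the scatter. That step exchanges the group on the amide-type nitrogen and leaves the nitro group untouched.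

Compound 3 `O=C(Cn1c(=O)oc2ccccc21)Nc1ccccn1` is not yet measured. It differs from compound 1 by hydrogen in place of nitro on an aromatic carbon. Going by the values given here, no measured step bears on this change, so the two numbers give no direct guide to its direction or size in this assay; a step in either direction, or none beyond the scatter, remains open. For compound 3 an estimate of 35% is made, with a range from 10% to 65%. The expected step is a number 12.3 percentage points lower from compound 1 to compound 3 (beyond the scatter), a wide and uncertain estimate.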

Compound 3, a percentage reported as inhibition, at one concentration (the size of the read-out at that concentration, not a potency): 28.4%
Compound 3: middle estimate off by 6.6 percentage points, on the high side; low and high end bracket the measured number.
By their numbers in this assay, from the lowest: compounds 2 and 3 (each within the scatter of the next); then compound 1.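

Hydrogen in place of nitro gives a number 18.9 percentage points lower from compound 1 to compound 3 (beyond the scatter) in this assay with the pyridin-2-yl amide held constant. The read-out therefore changes at this aromatic carbon as well as at the amide-type nitrogen, where phenyl in place of pyridin-2-yl gives a number 20.9 percentage points lower from compound 1 to compound 2 (beyond the scatter) as the other measured step from the same compound. No measurement at hand explains the change at this position.

Still open, going by these compounds, is whether the number follows nitro specifically or responds to any group other than hydrogen on this aromatic carbon, which an amine or a methoxy group there would help to settle. Also open, on these data alone, is whether the step from nitro to hydrogen keeps its direction and size when the amide-type nitrogen carries phenyl, as in compound 2, instead of pyridin-2-yl.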